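This account rests on a few compounds, and the source may have more. Where it says the series, first, only, none or still open, it means among the compounds named here.

Compound 1 `CC(C)c1nc(C(=O)NC[C@@H]2[C@H]3CN(CC4CCC4)C[C@@H]23)c2ccccn12`: 13.2 nM in a functional assay on CHO cells for agonist activity at 5-hydroxytryptamine receptor 4 (Homo sapiens), read by a luciferase reporter and cAMP accumulation, with a stated time of 4 h; a higher number here means that more compound is needed for the effect, a lower number that less compound is needed
Compound 2 `CC(C)c1nc(C(=O)NC[C@@H]2[C@H]3CN(CC(C)(C)CO)C[C@@H]23)c2ccccn12`: 5.7 nM in this assay

Compound 2 has the lower number of the two measured, with compound 1 set apart by a 2.3-fold lower number from compound 1 to compound 2 (0.36 log units; beyond the scatter). Compound 3 `COCC(C)(C)CN1C[C@@H]2[C@@H](CNC(=O)c3nc(C(C)C)n4ccccc34)[C@@H]2C1` is obtained from compound 2 by methyl in place of hydrogen on an oxygen on a saturated carbon, which caps the hydroxy group. Among the compounds with values here, no measured step touches this change directly; the only step on this chain, a 2.3-fold lower number from compound 1 to compound 2 (0.36 log units; beyond the scatter), swapped a ring for a hydroxymethyl-bearing chain and offers just an indirect hint. The expected step of a 1.4-fold higher number from compound 2 to compound 3 (0.15 log units; within the scatter) is therefore a small rise in the number, or none beyond the scatter. Compound 3 is estimated at 8 nM, within 3 nM to 25 nM.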

Compound 3, half-maximal effective concentration: 19.8 nM
The estimate for compound 3 lay 2.5-fold (0.39 log units) below the measured number; measured number inside the range.
By their numbers in this assay, from the lowest: compound 2; then compounds 1 and 3 (each within the scatter of the next).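

Putting methyl on the oxygen gives a 3.5-fold higher number from compound 2 to compound 3 (0.54 log units; beyond the scatter) in this assay, so at this position the hydroxy and methoxy forms are not interchangeable. The gain seen with the hydroxy chain is gone once it is capped: 1-(methoxymethyl)-1-methylethyl in place of cyclobutyl gives a 1.5-fold higher number from compound 1 to compound 3 (0.18 log units; within the scatter) and leaves compound 3 level with compound 1. Nothing available explains why this small change has such an effect. Still open, from the compounds shown here alone, is whether an amine in place of the hydroxy, or a longer chain carrying the hydroxy, would match compound 2.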